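Cyclohexyl for benzyl on the amide nitrogen of compound 1

The source may report more compounds than this note shows. Statements on the series, on what has been measured and on what is new or still open speak of the compounds shown alone.

Within the data shown here, in an ADME assay on HepG2 cells (Homo sapiens) for inhibition, read by luminescence and CellTiter-Glo, with stated times of 24 h and 48 h (on this read-out higher numbers stand for weaker inhibition and lower numbers for stronger inhibition), compound 1 (`Cc1ccc(C(=O)N(CC(=O)NCc2ccccc2)Cc2ccc(C(=O)NO)cc2)c(C)c1`) gives 3710 nM, the lower of the two numbers measured so far. Compound 2 (`Cc1ccccc1C(=O)N(CC(=O)NCc1ccccc1)Cc1ccc(C(=O)NO)cc1`) gives 9620 nM. Among the measured compounds shown here, the only measured step, a 2.6-fold higher number from compound 1 to compound 2 (0.41 log units; beyond the scatter), is modest but beyond the scatter, and it reflects hydrogen in place of methyl on an aromatic carbon.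

Compound 3 (`Cc1ccc(C(=O)N(CC(=O)NC2CCCCC2)Cc2ccc(C(=O)NO)cc2)c(C)c1`) instead carries cyclohexyl in place of benzyl on an amide-type nitrogen. For the measured compounds named here, no measured step involves this change, so that single step gives only a rough sense of scale and no direction. In this assay the likeliest outcome is no step beyond the scatter, although one as large as that step cannot be excluded.

The expected step is a 1.2-fold higher number from compound 1 to compound 3 (0.08 log units; within the scatter). The estimated value for compound 3 is 4500 nM, with an expected range of 1800 nM to 11000 nM.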

Compound 3, half-maximal inhibitory concentration: 8330 nM
The estimate for compound 3 lay 1.9-fold (0.27 log units) below the measured number; the measured number falls inside the stated range.
By their numbers in this assay, from the lowest: compound 1; then compounds 3 and 2 (each within the scatter of the next).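

In this assay, among these compounds, the amide-type nitrogen position proves responsive: cyclohexyl in place of benzyl gives a 2.2-fold higher number from compound 1 to compound 3 (0.35 log units; beyond the scatter), a modest step and the first reading at this position. Swapping the aromatic ring of benzyl for the non-aromatic ring of cyclohexyl therefore does not leave the number unchanged, and with a 2.6-fold higher number from compound 1 to compound 2 (0.41 log units; beyond the scatter) as well, both single changes from compound 1 raise the number. The data offer no measurement that explains this step.

Still open, on these data alone, is whether the step follows the loss of the aromatic ring or the change in how that ring is attached to the nitrogen. Phenyl or phenethyl on the same nitrogen would separate these readings, and an amine or carboxylic acid on the benzyl ring would show how far this position tolerates other groups.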